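The source may report more compounds than this note shows. Statements on the series, on what has been measured and on what is new or still open speak of the compounds shown alone.

Compound 2 `C[C@H](c1ccc(-c2ccccc2-c2nc(=O)o[nH]2)cc1)N(CC1CC1)c1nc2c(C(=O)O)cccc2o1` gives the highest number of the three measured in an ADME assay on the whole organism (Macaca fascicularis) for metabolic stability, read by LC-MS, using cassette dosing, at a dose of 1 mg/kg by the oral route; on this read-out higher numbers stand for a longer-lived compound and lower numbers for a shorter-lived compound: compound 2 records 2.6 h. Compound 3 `CCCCN(c1nc2c(C(=O)NC)cccc2o1)[C@H](C)c1ccc(-c2ccccc2-c2nnn[nH]2)cc1` stands nearest, giving 1.3 h in this assay, a gap within the scatter, so the two cannot be told apart. For the measured compounds named here, compound 1 `C[C@H](c1ccc(-c2cc(Cl)ccc2-c2nc(=O)o[nH]2)cc1)N(CC1CC1)c1nc2c(C(=O)O)cccc2o1` lies furthest from it; compound 1 gives 0.8 h in this assay, and the single step that separates them, a 3.3-fold higher number from compound 1 to compound 2 (0.51 log units; beyond the scatter), is the only change measured so far at a substituent on an aromatic carbon of the shared core.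

Compound 4 `Cc1ccc(-c2nc(=O)o[nH]2)c(-c2ccc([C@@H](C)N(CC3CC3)c3nc4c(C(=O)O)cccc4o3)cc2)c1` differs from compound 2 by methyl in place of hydrogen on an aromatic carbon. The step from compound 1 to compound 2 bears on this: there, taking a chloro off an aromatic carbon of the same kind lengthened the half-life modestly. Putting a small carbon group back onto such a carbon is therefore expected to move this assay in the opposite direction, by a modest step, though a methyl need not behave as a chloro did, so the step may also fall within the scatter.

On that basis compound 4 is expected to give about 1.5 h in this assay, within a range of 0.8 h to 2.8 h. That expectation corresponds to a 1.7-fold lower number from compound 2 to compound 4 (0.24 log units; within the scatter).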

Compound 4, half-life: 2.8 h
Estimate against measurement, compound 4: 1.9-fold (0.27 log units) below; low and high end bracket the measured number.
By their numbers in this assay, from the lowest: compounds 1, 3, 2 and 4 (each within the scatter of the next, the first and the last beyond it).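

In this assay, the first direct test of adding a group to this carbon, which is meta to a large group and para to a group of 6 heavy atoms, shows no readable change when methyl replaces hydrogen (a 1.1-fold higher number from compound 2 to compound 4 (0.03 log units; within the scatter)). The earlier step from chloro to hydrogen could not show whether any group at this carbon would go with a shorter half-life, but the methyl compound separates from the chloro compound (a 3.5-fold higher number from compound 1 to compound 4 (0.54 log units; beyond the scatter)) and not from the hydrogen compound, so among these three compounds the shorter half-life is seen with chloro alone. Nothing given here accounts for the difference between chloro and methyl at this carbon.

On these data alone, it stays open whether fluoro, methoxy, a longer chain such as ethyl or an amine at this carbon would track with hydrogen and methyl or with chloro. As far as these compounds go, it also stays open whether methyl would leave the half-life equally undisturbed on the tetrazole-bearing, butyl-substituted amide of compound 3, where this carbon still carries hydrogen.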